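The source may hold more compounds than are shown below. What is called first, only, known or untested is meant among the compounds shown, and "the series" means these compounds.

Measured compounds:
Compound 1, `COc1cc(/C=N/c2c(C#N)ncn2-c2ccc(F)cc2)ccc1O`, gives 9990 nM in a functional assay on MCF7 cells (Homo sapiens) for antiproliferative activity, read by MTT assay, with a stated time of 48 h; on this read-out higher numbers stand for weaker inhibition and lower numbers for stronger inhibition.
Compound 2, `N#Cc1ncn(-c2ccc(F)cc2)c1/N=C/c1ccc(O)cc1`, gives 11500 nM in this assay.
Compound 3, `COc1ccc(/C=N/c2c(C#N)ncn2Cc2ccc(F)cc2)cc1OC`, gives 11100 nM in this assay.

Among the measured compounds shown here, the one measured step, a 1.2-fold lower number from compound 2 to compound 1 (0.06 log units; within the scatter), comes from the change (methoxy in place of hydrogen on an aromatic carbon), where the entering group sits ortho to a hydroxy group and meta to a large group. Compound 4, `COc1ccc(/C=N/c2c(C#N)ncn2Cc2ccc(F)cc2)c(OC)c1OC`, differs from compound 3 by the same kind of change, (methoxy in place of hydrogen on an aromatic carbon), but here the place is ortho to a large group, ortho to a methoxy group and meta to a methoxy group. The difference between the cores of compound 2 and compound 3 is not broken down here. Resting on that measured step, the step of a 1.1-fold lower number from compound 3 to compound 4 (0.02 log units; within the scatter) in this assay is expected to stay small, so compound 4 is estimated at 10500 nM, between 5000 nM and 22000 nM.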

Compound 4, half-maximal inhibitory concentration: 12600 nM
Compound 4: middle estimate off by 1.2-fold (0.08 log units), on the low side; low and high end bracket the measured number.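

In this assay the added methoxy group gives a 1.1-fold higher number from compound 3 to compound 4 (0.06 log units; within the scatter) and so stays as small on this core as on the earlier one. Among the compounds shown here, this shows only that the change made no measurable difference at the two places tried, each on its own core; it does not show that the same would hold at another place or on another core, and such small steps cannot show what a larger effect would carry over. The two steps agree as far as these numbers can tell: the same change on two cores in this assay, a 1.2-fold lower number (0.06 log units; within the scatter) from compound 2 to compound 1 and a 1.1-fold higher number (0.06 log units; within the scatter) from compound 3 to compound 4, 1.3-fold (0.12 log units) apart, within the scatter of two such steps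

The compounds shown leave open whether an amine or a carboxylic acid on the aromatic ring in place of a methoxy group would move the number beyond the scatter. They also leave open whether a longer chain in place of methoxy would do so.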